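Swapping an aryl amine for a benzyl amine

The source may report more compounds than this note shows. Statements on the series, on what has been measured and on what is new or still open speak of the compounds shown alone.

Compound 1 `Cc1ccc(NC2=CC(=O)c3nc4n(c3C2=O)[C@H]2OC[C@@H](O)[C@H]2OC4)cc1` and compound 2 `CCCc1ccc(NC2=CC(=O)c3c(nc4n3[C@H]3OC[C@@H](O)[C@H]3OC4)C2=O)cc1` share a core and differ only in the group on the amine nitrogen. In a functional assay on MGC-803 cells (Homo sapiens) for inhibition, read by sulforhodamine B assay (a higher number here means a weaker inhibitor, a lower number a stronger inhibitor), compound 1 gives 1420 nM, the lower of the two numbers, while compound 2 gives 1920 nM; the two lie within the scatter of each other. Compound 3 `O=C1C=C(NCc2ccccc2)C(=O)c2c1nc1n2[C@H]2OC[C@@H](O)[C@H]2OC1` has not yet been measured in this assay. It differs from compound 1 in one place: benzyl in place of 4-methylphenyl on an amine nitrogen. Within the data shown here, with no measured step of this kind to lean on, compound 3 is expected to be a somewhat weaker inhibitor, with the step of a 1.8-fold higher number from compound 1 to compound 3 (0.25 log units; within the scatter) small and not clearly beyond the scatter. Compound 3 is estimated at 2500 nM in this assay, within a range from 800 nM to 8000 nM.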

Compound 3, half-maximal inhibitory concentration: 2670 nM
For compound 3 the middle estimate is 1.1-fold (0.03 log units) below the measured one; measured number inside the range.
By their numbers in this assay, from the lowest: compounds 1, 2 and 3 (each within the scatter of the next).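

In this assay, among these compounds, benzyl in place of 4-methylphenyl on the amine nitrogen gives a 1.9-fold higher number from compound 1 to compound 3 (0.27 log units; within the scatter) and is the only measured step at this position. Two groups of equal heavy-atom count, joined differently, are therefore not separated by this read-out. No measurement shown here accounts for the step. On these data alone, whether 2-phenylethyl, cyclohexylmethyl or a carboxylic acid carried on the benzyl group would give a step beyond the scatter remains open. So does whether a simple alkyl chain on this nitrogen would do so.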